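This account rests on a few compounds, and the source may have more. Where it says the series, first, only, none or still open, it means among the compounds named here.

Measured so far:
Compound 1, `COc1ccc(-c2cc(=O)c3c(OC)cc(OC)cc3n2S(=O)(=O)c2ccc(Br)cc2)cc1`: in a functional assay on KOPN-8 cells (Homo sapiens) for antiproliferative activity, with a stated time of 72 h (a higher number here means that more compound is needed for the effect, a lower number that less compound is needed), compound 1 reaches only a limit, > 86200 nM.
Compound 2, `COC(=O)c1cc(=O)c2cc(NC(=O)Nc3cccc(C(C)=O)c3)ccc2[nH]1`: in this assay compound 2 reaches only a limit, > 8080 nM.
Compound 3, `C=C(C)c1cccc(C(C)(C)NC(=O)Nc2ccc3[nH]c(C(=O)OC)cc(=O)c3c2)c1`: in this assay compound 3 reaches only a limit, > 11500 nM.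

Compound 2 therefore stands at a limit, not at a number, as shown by the limit of > 8080 nM in this assay, at which 1 of the 3 values shown sits; the other two values are likewise limits, the limit of > 11500 nM in this assay, at which 1 of the 3 values shown sits, and (the limit of > 86200 nM in this assay, at which 1 of the 3 values shown sits), so no ordering among the three can be read.

Compound 4, `COC(=O)c1cc(=O)c2cc(NC(=O)Nc3ccc4c(c3)CCC4)ccc2[nH]1`, differs from compound 2 by 2,3-dihydro-1H-inden-5-yl in place of 3-acetylphenyl on an amide-type nitrogen. For the measured compounds named here, no measured step covers this change. With every value in this assay a limit, the expectation for the step from compound 2 to compound 4 is none beyond the scatter, a step that the limit leaves unreadable from compound 2 to compound 4. For compound 4 the estimated value in this assay is 15000 nM, range 4000 nM to 60000 nM, most likely reported again as a limit.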

Compound 4, half-maximal effective concentration: > 24100 nM
Compound 4: only a limit was reported; the forecaster's own chance of this, stated with the estimate: 80%; at least 1.6-fold (0.20 log units) between middle value and limit.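

Compound 2 and compound 4 both give only limits in this assay, so no step can be read between them. The compounds shown leave open whether 2,3-dihydro-1H-inden-5-yl in place of 3-acetylphenyl changes the antiproliferative effect at all.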